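Para substituent swap on the aniline ring of the pyranone series

The source may hold more compounds than are shown below. What is called first, only, known or untested is meant among the compounds shown, and "the series" means these compounds.

Measured so far:
compound 1 `Cc1ccc(Nc2cc(-c3ccccc3)oc(=O)c2)cc1` — 0.067 uM
compound 2 `COc1ccc(Nc2cc(-c3ccccc3)oc(=O)c2)cc1` — 0.093 uM

In a functional assay on A549 cells (Homo sapiens) for cytotoxicity, read by MTT assay, with a stated time of 72 h (a higher number here means that more compound is needed for the effect, a lower number that less compound is needed), compound 1 gives 0.067 uM and compound 2 gives 0.093 uM. Compound 2 holds the highest of the two numbers, but the gap to compound 1, a 1.4-fold higher number from compound 1 to compound 2 (0.14 log units; within the scatter), is within the scatter, so the two cannot be ordered.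

Compound 3 `O=c1cc(Nc2ccc(Br)cc2)cc(-c2ccccc2)o1` is not yet measured. It differs from compound 2 by bromo in place of methoxy on an aromatic carbon. Among the measured compounds shown here, the only measured step that bears on this position is the exchange of methyl for methoxy at the same place, a 1.4-fold higher number from compound 1 to compound 2 (0.14 log units; within the scatter), which stayed within the scatter. For the measured compounds named here, no measured step covers a halogen there.

On that basis the step of a 1.2-fold lower number from compound 2 to compound 3 (0.07 log units; within the scatter) is expected to be small, with no clear direction beyond the scatter. Compound 3 is therefore estimated at 0.08 uM, with a range from 0.03 uM to 0.25 uM in this assay.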

Compound 3, concentration for half-maximal effect: 0.31 uM
Compound 3: the middle estimate sits 3.9-fold (0.59 log units) below what was measured; the measured number lies above the stated range.
By their numbers in this assay, from the lowest: compounds 1 and 2 (each within the scatter of the next); then compound 3.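

In this assay this position, on an aromatic carbon para to a large group, proves sensitive to the group it carries: bromo in place of methoxy gives a 3.3-fold higher number from compound 2 to compound 3 (0.52 log units; beyond the scatter) and bromo in place of methyl gives a 4.6-fold higher number from compound 1 to compound 3 (0.67 log units; beyond the scatter) in the same series. The methyl and methoxy pair alone could not show this, since those two stay within the scatter of each other, whereas bromo separates from both, though both steps are modest in size. Nothing at hand explains why bromo stands apart from methyl and methoxy.

On these data alone, whether the step belongs to bromo alone or to halogens at this place remains open, and chloro or fluoro would address that. As far as these compounds go, how an amine or a carboxylic acid at the same carbon would compare also remains open.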